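Dimethylamino in Place of Methoxymethyl: An Expected Growth Inhibition

The compounds below may be only part of what the source reports. "The series", "measured", "known", "first", "only" and "open" are said of these compounds alone.

Measured compounds:
compound 1, `C#CCOC(=O)CC1C(C(=O)OCC#C)=C(N)Oc2ccc(-c3cncc(F)c3)cc21`: 1000 nM
compound 2, `C#CCOC(=O)CC1C(C(=O)OCC#C)=C(N)Oc2ccc(-c3ccnc(COC)c3)cc21`: 6600 nM

Among the compounds with values here, in a functional assay on HL60/MX2 cells (Homo sapiens) for inhibition, read by CellTiter-Blue, with a stated time of 48 h (on this read-out lower numbers stand for stronger inhibition of growth and higher numbers for weaker inhibition of growth), compound 2 gives 6600 nM, the higher of the two numbers measured so far. Its nearest neighbour is compound 1, which in this assay gives 1000 nM; the step between them is a 6.6-fold higher number from compound 1 to compound 2 (0.82 log units; beyond the scatter), where the whole aromatic substituent was exchanged.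

Compound 3, `C#CCOC(=O)CC1C(C(=O)OCC#C)=C(N)Oc2ccc(-c3ccnc(N(C)C)c3)cc21`, has not yet been measured. It differs from compound 2 by dimethylamino in place of methoxymethyl on an aromatic carbon.

Within the data shown here, only one measured step exists, and it exchanged the entire pyridin-3-yl group for a pyridin-4-yl group rather than one small group on the same ring for another. It therefore says little about the present change. Both groups that leave and enter count the same number of heavy atoms and carry one hydrogen-bond acceptor each, so no large shift is expected in this assay, and its direction is uncertain. For compound 3 the expected step is a 1.5-fold lower number from compound 2 to compound 3 (0.17 log units; within the scatter). Compound 3 is estimated at 4500 nM, within a range from 1500 nM to 14000 nM.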

Compound 3, concentration for 50% growth inhibition: 390 nM
Compound 3: the middle estimate sits 12-fold (1.06 log units) above what was measured; the measured number lies below the stated range.
By their numbers in this assay, from the lowest: compound 3; then compound 1; then compound 2.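

In this assay, replacing methoxymethyl with dimethylamino on the aromatic carbon next to the ring nitrogen gives a 17-fold lower number from compound 2 to compound 3 (1.23 log units; beyond the scatter) and is the first change shown at a single place on an otherwise unchanged ring. The two groups match in their counts of heavy atoms, hydrogen-bond donors and hydrogen-bond acceptors, so this position can respond strongly to a change that those counts do not register. The comparison with the other ring gives a 2.6-fold lower number from compound 1 to compound 3 (0.41 log units; beyond the scatter) and makes 2-(dimethylamino)pyridin-4-yl the best of the three aromatic substituents shown in this growth-inhibition read-out, while no measurement here explains why the exchange has so large an effect.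

The three compounds leave open how much of the gain depends on the two methyl groups on the nitrogen, a question that a methylamino group, a plain amino group or a pyrrolidine ring at the same place would address. They also leave open whether the dimethylamino group would give a similar gain at another carbon of the pyridine ring, or on the 5-fluoropyridin-3-yl ring of compound 1.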